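Swapping the Amine at the End of the Side Chain

The compounds below may be only part of what the source reports. "The series", "measured", "known", "first", "only" and "open" are said of these compounds alone.

Compound 1 `CC(C)N1CCC(Oc2ccc(-c3nc4ccc(Oc5ccc(Cl)cc5)cc4o3)cc2)CC1`: 12.7%
Compound 2 `CN(C)CCCOc1ccc(-c2nc3ccc(Oc4ccc(Cl)cc4)cc3o2)cc1`: 4.9%

In an assay on isolated protein for inhibition of advanced glycosylation end product-specific receptor (Homo sapiens), read by FRET, with stated times of 30 min and 1 h, tested at 4 uM (on this read-out higher numbers stand for more inhibition at the one concentration tested (going by the name of the read-out) and lower numbers for less inhibition), compound 2 gives 4.9%, the lowest of the two numbers shown, yet within the usual scatter of compound 1, which gives 12.7%. Compound 3 `Clc1ccc(Oc2ccc3nc(-c4ccc(OCCCN5CCCC5)cc4)oc3c2)cc1` differs from compound 2 by pyrrolidin-1-yl in place of dimethylamino on a saturated chain carbon, three bonds along the chain from an oxygen on an aromatic ring. Among the compounds with values here, the only measured step that bears on this region is a number 7.8 percentage points lower from compound 1 to compound 2 (within the scatter), an exchange of the amine-bearing side chain that did not move the read-out beyond the scatter. A change of the same kind is therefore expected to give no step beyond the scatter: a number 2.1 percentage points higher from compound 2 to compound 3 (within the scatter). Compound 3 is estimated at 7%, with a range from 0% to 20%.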

Compound 3, a percentage reported as inhibition, at one concentration (the size of the read-out at that concentration, not a potency): "not active" (no number reported)
Compound 3: no number reported, and the estimate cannot be compared.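

Within the data shown here, compound 3 is reported as "not active" without a number, and no step from compound 2 to compound 3 can be read. Nothing measured here offers an explanation. Going by these compounds, how far pyrrolidin-1-yl in place of dimethylamino shifts the inhibition stays open.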